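The compounds below may be only part of what the source reports. "The series", "measured", "known", "first", "only" and "open" are said of these compounds alone.

Values in a functional assay for inhibition, with Homo sapiens as the target; a lower number here means tighter binding, a higher number weaker binding:
- Compound 1 `CC(C)(Oc1ccccc1O)C1OCC(C/C=C\CCC(=O)O)C(c2cccnc2)O1`: 95.5 nM
- Compound 2 `Cc1ccc(SC(C)(C)C2OCC(C/C=C\CCC(=O)O)C(c3cccnc3)O2)c([N+](=O)[O-])c1`: 158 nM
- Compound 3 `CC(C)(C1OCC(C/C=C\CCC(=O)O)C(c2cccnc2)O1)S(=O)(=O)c1ccccc1`: 3160 nM

Compound 3 has the highest number of the three in this assay, at 3160 nM. The other two compounds do not separate, with a 1.7-fold higher number from compound 1 to compound 2 (0.22 log units; within the scatter).

Compound 4 `CC(C)(Cc1ccc(F)cc1C#N)C1OCC(C/C=C\CCC(=O)O)C(c2cccnc2)O1` differs from compound 3 in one place: a group of 10 heavy atoms (8 carbon, 1 nitrogen, 1 fluorine; one six-membered aromatic ring of carbon only) in place of a group of 9 heavy atoms (6 carbon, 2 oxygen, 1 sulfur; one six-membered aromatic ring of carbon only), on a saturated chain carbon bound to two saturated chain carbons and a saturated ring carbon. Phenylsulfonyl leaves, on a saturated chain carbon bound to two saturated chain carbons and a saturated ring carbon.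

Going by the values given here, two measured steps bear on this change, and both end at compound 3. They are a 33-fold higher number from compound 1 to compound 3 (1.52 log units; beyond the scatter) and a 20-fold higher number from compound 2 to compound 3 (1.30 log units; beyond the scatter). Both are large, and neither compound 1 nor compound 2 carries phenylsulfonyl. Among the compounds with values here, removing that group is therefore expected to lower the number, though the entering group appears in no measured compound. Full recovery to the level of compound 2, at 158 nM, cannot be assumed, so only part of the large steps is carried over.

The expected change is an 11-fold lower number from compound 3 to compound 4 (1.02 log units; beyond the scatter), a lower number. The estimate for compound 4 is 300 nM, with an expected range of 70 nM to 1500 nM.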

Compound 4, dissociation constant: 2.19 nM
For compound 4 the middle estimate is 140-fold (2.14 log units) above the measured one; the measured number lies below the stated range.
By their numbers in this assay, from the lowest: compound 4; then compounds 1 and 2 (each within the scatter of the next); then compound 3.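

At the saturated chain carbon bound to two saturated chain carbons and a saturated ring carbon, the entering group does more than remove the penalty seen with phenylsulfonyl: in this assay the change gives (a 1400-fold lower number from compound 3 to compound 4 (3.16 log units; beyond the scatter)). Going by these compounds alone, it also goes well past the two compounds without phenylsulfonyl (a 72-fold lower number from compound 2 to compound 4 (1.86 log units; beyond the scatter); a 44-fold lower number from compound 1 to compound 4 (1.64 log units; beyond the scatter)), so the level shared within the scatter by compound 1 and compound 2 is not a floor for this position, and the group here can move the number much further than the earlier compounds showed. Nothing available explains why this group gives so low a number.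

The compounds shown do not separate the contributions of the nitrile, the fluorine and the carbon link to the aromatic ring, so it remains open which of these features carries the gain, or whether it needs them together. Also open, from the compounds shown here alone, is how a plain benzyl group, or a primary amide in place of the nitrile, would read in this assay at this position.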